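Replacing 2-Methylphenyl with 4-Iodophenyl: an Expected Gain

The compounds below may be only part of what the source reports. "The series", "measured", "known", "first", "only" and "open" are said of these compounds alone.

Compound 1 `Cc1ccccc1-n1cc(COc2cccc(NC(=O)Nc3ccc(Cl)c(C(F)(F)F)c3)c2)nn1`: 3440 nM
Compound 2 `O=C(Nc1cccc(OCc2cn(-c3cccc(Br)c3)nn2)c1)Nc1ccc(Cl)c(C(F)(F)F)c1`: 1040 nM

Of the two measured compounds, compound 1 stands highest in a functional assay on HepG2 cells (Homo sapiens) for inhibition, read by MTT assay, with a stated time of 72 h; a lower number here means a stronger inhibitor, a higher number a weaker inhibitor; compound 2 sits lower by a 3.3-fold lower number from compound 1 to compound 2 (0.52 log units; beyond the scatter). Compound 3 `O=C(Nc1cccc(OCc2cn(-c3ccc(I)cc3)nn2)c1)Nc1ccc(Cl)c(C(F)(F)F)c1` is not yet measured and differs from compound 1 by 4-iodophenyl in place of 2-methylphenyl on an aromatic nitrogen. Going by the values given here, the only measured step that bears on this change is a 3.3-fold lower number from compound 1 to compound 2 (0.52 log units; beyond the scatter), which likewise removed the 2-methylphenyl and gave a modest drop beyond the scatter. A step of similar size and direction is therefore expected, namely a 2.6-fold lower number from compound 1 to compound 3 (0.42 log units; beyond the scatter). Compound 3 is estimated at 1300 nM, with a range from 500 nM to 3500 nM.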

Compound 3, half-maximal inhibitory concentration: 2690 nM
Compound 3: middle estimate off by 2.1-fold (0.32 log units), on the low side; low and high end bracket the measured number.
By their numbers in this assay, from the lowest: compound 2; then compounds 3 and 1 (each within the scatter of the next).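

Losing the 2-methylphenyl does not lower the number by itself: with 4-iodophenyl on the aromatic nitrogen, the change stays within the scatter (a 1.3-fold lower number from compound 1 to compound 3 (0.11 log units; within the scatter)). A halogen on this phenyl ring therefore does not guarantee a gain, and 4-iodophenyl in place of 3-bromophenyl gives a modest rise beyond the scatter (a 2.6-fold higher number from compound 2 to compound 3 (0.41 log units; beyond the scatter)). No available evidence explains this difference.

The 3-bromophenyl and 4-iodophenyl groups differ in both halogen and ring position, so these compounds cannot separate the two. On these data alone, how 4-bromophenyl or 3-iodophenyl would behave here remains open.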